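Compound 3: a dimethylamino step from compound 2

The source may report more compounds than this note shows. Statements on the series, on what has been measured and on what is new or still open speak of the compounds shown alone.

Of the compounds shown here, two carry numbers so far. In a functional assay on MCF7 cells (Homo sapiens) for inhibition, read by sulforhodamine B assay (a lower number here means a stronger inhibitor of growth, a higher number a weaker inhibitor of growth), compound 1 (`Oc1ccc(-c2ccc(-c3ccc(-c4nc5ccccc5[nH]4)cc3)cc2)cc1`) gives 30500 nM as its concentration for half growth inhibition, and compound 2 (`Oc1cccc2[nH]c(-c3ccc(-c4ccc(-c5ccccc5)cc4)cc3)nc12`) gives 2200 nM as the lower of the two numbers. Compound 2 is therefore the stronger inhibitor of growth of the pair, and its gap to compound 1 lies beyond the usual scatter.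

The next compound to be read is compound 3 (`CN(C)c1ccc(-c2ccc(-c3ccc(-c4nc5c(O)cccc5[nH]4)cc3)cc2)cc1`). The change from compound 2 to compound 3 is dimethylamino in place of hydrogen on an aromatic carbon and it puts dimethylamino in place of hydrogen on an aromatic carbon of a six-membered aromatic ring of carbon only, para to a large group. For the measured compounds named here, no measured pair shows what this change does in this assay so the expectation rests on little. The expected move is a 1.4-fold higher number from compound 2 to compound 3 (0.13 log units; within the scatter) and no step beyond the scatter is expected, with any drift going toward a higher number. For compound 3 the estimated value is 3000 nM with an expected range from 800 nM to 12000 nM as the working figure.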

Compound 3, concentration for 50% growth inhibition: 2310 nM
The estimate for compound 3 lay 1.3-fold (0.11 log units) above the measured number; low and high end bracket the measured number.
By their numbers in this assay, from the lowest: compounds 2 and 3 (each within the scatter of the next); then compound 1.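

On the six-membered aromatic ring of carbon only, para to a large group, the change from phenyl to 4-(dimethylamino)phenyl gives a 1.1-fold higher number from compound 2 to compound 3 (0.02 log units; within the scatter) in this assay, so the two compounds cannot be told apart in this read-out. Until now this place had a reading only with hydrogen on it; the pair now shows that dimethylamino, a group of several heavy atoms with no ring and no net charge, can stand there without a step beyond the scatter. No measurement is available that would explain this result or connect it to any property of the group.

Going by these compounds, a single substituent at a single place does not describe the place as a whole, so it remains open whether a primary amine, a carboxylic acid or a longer chain such as butoxy would also stay within the scatter of hydrogen here. On these data alone, it also remains open whether dimethylamino would give a step of the same size at another place on the shared core, or on a core carrying its hydroxyl elsewhere.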